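Thiophen-3-yl in Place of Pyridin-4-yl: An Expected Value

The source may hold more compounds than are shown below. What is called first, only, known or untested is meant among the compounds shown, and "the series" means these compounds.

Compound 1 `CC(C)(C)Cc1c(-c2ccncc2)sc(N)c1C(=O)c1ccc(Cl)cc1` gives 6% in an assay on CHO cells for displacement of a labelled ligand from adenosine receptor A3 (Homo sapiens), read by scintillation counting, tested at 10 uM; on this read-out lower numbers stand for less inhibition and higher numbers for more inhibition at the one concentration tested (going by the name of the read-out).
Compound 2 `CC(C)(C)Cc1c(Br)sc(N)c1C(=O)c1cccc(C(F)(F)F)c1` gives 4% in this assay.
Compound 3 `CC(C)(C)Cc1c(-c2ccccc2)sc(N)c1C(=O)c1cccc(C(F)(F)F)c1` gives 1% in this assay.

On these numbers compound 1 holds the highest value of the three, yet compound 2 lies nearest and compound 3 furthest, both within the usual scatter, so the three cannot be told apart. Compound 4 `CC(C)(C)Cc1c(-c2ccsc2)sc(N)c1C(=O)c1ccc(Cl)cc1` is not yet measured; it differs from compound 1 by thiophen-3-yl in place of pyridin-4-yl on an aromatic carbon. Going by the values given here, the only measured step, a number 3 percentage points lower from compound 2 to compound 3 (within the scatter), concerns a different exchange and stays within the scatter. Among the compounds with values here, no step swaps one aromatic ring for another, so no change beyond the scatter is expected, estimated as a number 1 percentage points lower from compound 1 to compound 4 (within the scatter). Compound 4 is therefore expected to give 5%, in a range from 0% to 15%.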

Compound 4, a percentage reported as inhibition, at one concentration (the size of the read-out at that concentration, not a potency): 4%
Compound 4: the middle estimate sits 1 percentage points above what was measured; low and high end bracket the measured number.
By their numbers in this assay, from the lowest: compounds 3, 2, 4 and 1 (each within the scatter of the next).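

In this assay, putting thiophen-3-yl in place of pyridin-4-yl on the aromatic carbon next to the ring sulfur gives a number 2 percentage points lower from compound 1 to compound 4 (within the scatter). This is the first step shown that exchanges one aromatic ring for another, and here a six-membered ring with nitrogen gives way to a five-membered ring with sulfur without a step beyond the scatter. No measurement shown offers an explanation for this result.

Going by these compounds, whether a carboxylic acid or a morpholine ring at this carbon would move the number beyond the scatter remains open.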